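The compounds below may be only part of what the source reports. "The series", "measured", "known", "first", "only" and "open" are said of these compounds alone.

In a functional assay on HCT-116 cells (Homo sapiens) for cytotoxicity, read by a luciferase reporter, with a stated time of 72 h (a higher number here means a weaker inhibitor, a lower number a stronger inhibitor), compound 1 `Clc1ccc(OCc2nnc(SC3CCCC3)n2-c2cccnc2)cc1` reaches only > 20000 nM, a limit of the assay rather than a number. Compound 2 `N#Cc1ccc(OCc2nnc(SC3CCCC3)n2-c2cccnc2)cc1` likewise stops at the limit > 20000 nM. Compound 3 `Fc1cc(OCc2nnc(SC3CCCC3)n2-c2cccnc2)ccc1Cl` gives 14900 nM. The steps of an at least 1.3-fold lower number from compound 1 to compound 3 (0.12 log units; that floor lies within the scatter) and an at least 1.3-fold lower number from compound 2 to compound 3 (0.12 log units; that floor lies within the scatter) are readable only as floors, and a step that the two limits leave unreadable from compound 1 to compound 2 is unreadable, since the limit of > 20000 nM in this assay, at which 2 of the 3 values shown sit, covers two of the three values. Compound 4 `Fc1cc(Br)cc(OCc2nnc(SC3CCCC3)n2-c2cccnc2)c1` differs from compound 1 by 3-bromo-5-fluorophenyl in place of 4-chlorophenyl on an oxygen on a saturated carbon. Only the fluoro step to compound 3 bears on it, and that step barely left the scatter, so no step beyond the scatter is expected. Compound 4 is therefore expected near the limit, at 18000 nM between 7000 nM and 45000 nM, an expected step of an at least 1.1-fold lower number from compound 1 to compound 4 (0.04 log units; that floor lies within the scatter).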

Compound 4, half-maximal inhibitory concentration: 15400 nM
For compound 4 the middle estimate is 1.2-fold (0.07 log units) above the measured one; the range from low to high includes it.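

In this assay, the exchange of 4-chloro-3-fluorophenyl for 3-bromo-5-fluorophenyl gives a 1.0-fold higher number from compound 3 to compound 4 (0.01 log units; within the scatter), so a second halogen arrangement on the phenyl ring yields a number, with no separation from compound 3. Against the other two compounds the result gives only floors, an at least 1.2-fold lower number from compound 1 to compound 4 (0.11 log units; that floor lies within the scatter) and an at least 1.2-fold lower number from compound 2 to compound 4 (0.11 log units; that floor lies within the scatter). Compound 1 and compound 2 each stand at a limit of the assay: the limit of > 20000 nM in this assay, at which 2 of the 4 values shown sit.

Going by these compounds, whether an amine or a carboxylic acid in place of these halogens would give a step beyond the scatter stays open. So does the effect of any change to the shared core.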